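Dropping both substituents from the aryl ring on the ring nitrogen

This account rests on a few compounds, and the source may have more. Where it says the series, first, only, none or still open, it means among the compounds named here.

Compound 3 `COc1ccc(F)cc1N1C(=O)CSC1c1cccc(C(=O)NCCCCc2ccccc2)c1` holds the highest of the three numbers in a functional assay on HOS cells (Homo sapiens) for inhibition, read by CCK-8 assay, with a stated time of 72 h, tested at 1 uM; a higher number here means more inhibition at the concentration tested (going by the name of the read-out), a lower number less inhibition: it gives 46%, while compound 1 `COc1ccc(C)cc1N1C(=O)CSC1c1cccc(C(=O)NCCCCc2ccccc2)c1` gives 42% and compound 2 `COc1ccc(OC)c(N2C(=O)CSC2c2cccc(C(=O)NCCCCc3ccccc3)c2)c1` gives 5%. The step of a number 4 percentage points higher from compound 1 to compound 3 (within the scatter) lies within the scatter, whereas a number 41 percentage points higher from compound 2 to compound 3 (beyond the scatter) and a number 37 percentage points lower from compound 1 to compound 2 (beyond the scatter) are large. Compound 4 `O=C(NCCCCc1ccccc1)c1cccc(C2SCC(=O)N2c2ccccc2)c1` differs from compound 3 by phenyl in place of 5-fluoro-2-methoxyphenyl on an amide-type nitrogen in a ring. All three measured steps change one group on that ring; none removes the methoxy, so the bearing is indirect. Since a single exchange on this ring already moved this assay by a number 41 percentage points higher from compound 2 to compound 3 (beyond the scatter), a sizable shift is possible in either direction. Compound 4 is expected to give 30%, between 5% and 55%, a step of a number 16 percentage points lower from compound 3 to compound 4 (beyond the scatter).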

Compound 4, a percentage reported as inhibition, at one concentration (the size of the read-out at that concentration, not a potency): 55%
For compound 4 the middle estimate is 25 percentage points below the measured one; the range from low to high includes it.
By their numbers in this assay, from the lowest: compound 2; then compounds 1, 3 and 4 (each within the scatter of the next, the first and the last beyond it).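

In this assay, the unsubstituted phenyl on the ring nitrogen retains the inhibition: the steps are a number 9 percentage points higher from compound 3 to compound 4 (within the scatter), a number 13 percentage points higher from compound 1 to compound 4 (beyond the scatter) and a number 50 percentage points higher from compound 2 to compound 4 (beyond the scatter). The substituents on this aryl ring are therefore not required for this read-out at the concentration tested, and among these compounds only 2,5-dimethoxyphenyl stands far below the others. No supporting data bear on the reason for this. The compounds shown leave open how a phenyl carrying only the methoxy or only the fluoro would behave. They also leave open what an amine or a carboxylic acid on this phenyl would do.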